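The compounds below may be only part of what the source reports. "The series", "measured", "known", "first", "only" and "open" are said of these compounds alone.

Compound 1 `COc1cccc(-n2cc3nc(-c4cccnc4C)n(C[C@H]4CCCN(CC5CCCCC5)C4)c(=O)c3n2)c1`, compound 2 `Cc1ncccc1-c1nc2cn(-c3cccc(OC(F)F)c3)nc2c(=O)n1C[C@H]1CCCN(C[C@H]2CCCO2)C1` and compound 3 `Cc1ccccc1-c1nc2cn(-c3ccc(Cl)cc3)nc2c(=O)n1CC1CCCN(C(C)C)C1` share the same core and have been run in an assay on HEK293 cells for displacement of a labelled ligand from growth hormone secretagogue receptor type 1 (Homo sapiens), with a stated time of 60 min; a higher number here means a weaker inhibitor, a lower number a stronger inhibitor. In this assay compound 1 gives 200 nM, the highest of the three numbers. Compound 2 gives 27 nM in this assay, the nearest number to compound 1, and compound 3 gives 0.28 nM, the furthest; both gaps lie beyond the scatter, so compound 1 is the weakest inhibitor of the three. Compound 4 `COc1cccc(-n2cc3nc(-c4cccnc4C)n(C[C@H]4CCCN(CC5CCCCO5)C4)c(=O)c3n2)c1` has not yet been measured. It differs from compound 1 in one place: oxan-2-yl in place of cyclohexyl on a saturated chain carbon bound to an amine nitrogen in a ring. Among the compounds with values here, no measured pair shows this change on its own, and compound 2 differs from compound 1 in more than one place, so its value is no clean guide. The step of a 1.3-fold lower number from compound 1 to compound 4 (0.12 log units; within the scatter) is expected to be small, toward a lower number, and may fall within the scatter. Compound 4 is estimated at 150 nM, within 50 nM to 450 nM.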

Compound 4, half-maximal inhibitory concentration: 120 nM
Beside the measured number, compound 4's estimate is 1.3-fold (0.10 log units) above it; the range from low to high includes it.
By their numbers in this assay, from the lowest: compound 3; then compound 2; then compounds 4 and 1 (each within the scatter of the next).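

In this assay, within the data shown here, the change to oxan-2-yl in place of cyclohexyl on a saturated chain carbon bound to an amine nitrogen in a ring gives a 1.7-fold lower number from compound 1 to compound 4 (0.22 log units; within the scatter) and is the first clean reading at this position. Exchanging a ring carbon for oxygen, which adds one hydrogen-bond acceptor, therefore produces no step beyond the scatter on this core. Nothing available bears on the reason for this result. Still open, from the compounds shown here alone, is whether a ring amine such as piperidin-2-yl or an open methoxyethyl chain would behave alike here. Going by these compounds, whether the same exchange reads the same on other aryl groups of the shared core also remains open.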